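A few compounds are considered here, and "the series" means these few. Any claim that something is new, unique, unknown or untested is made for them only; others in the source may bear on it.

Measured so far in a functional assay on HCT-116 cells (Homo sapiens) for cytotoxicity, read by MTT assay, with a stated time of 48 h; a higher number here means a weaker inhibitor, a lower number a stronger inhibitor:
- compound 1 `O=C(/C=C/c1ccc2c(c1)B(O)OC2)c1ccc(F)cc1` gives 2800 nM
- compound 2 `CSc1ccc(C(=O)/C=C/c2ccc3c(c2)B(O)OC3)cc1` gives 10300 nM

Compound 2 stands highest of these two numbers; the step of a 3.7-fold higher number from compound 1 to compound 2 (0.57 log units; beyond the scatter) shows how it compares with compound 1. Compound 3 `Nc1ccc(C(=O)/C=C/c2ccc3c(c2)B(O)OC3)cc1` differs from compound 2 by amino in place of methylsulfanyl on an aromatic carbon. For the measured compounds named here, no measured step exchanges methylsulfanyl for amino; the only step known, a 3.7-fold higher number from compound 1 to compound 2 (0.57 log units; beyond the scatter), concerns a different exchange at the same carbon and gives no direction for this one. The step of a 1.5-fold lower number from compound 2 to compound 3 (0.17 log units; within the scatter) is therefore expected to be small, within the scatter. For compound 3 in this assay, a value of 7000 nM is estimated, between 2000 nM and 25000 nM.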

Compound 3, half-maximal inhibitory concentration: 26100 nM
For compound 3 the middle estimate is 3.7-fold (0.57 log units) below the measured one; the measured number lies above the stated range.
By their numbers in this assay, from the lowest: compound 1; then compound 2; then compound 3.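

For the compounds shown here, at this aromatic carbon, this assay now separates three groups: amino in place of methylsulfanyl gives a 2.5-fold higher number from compound 2 to compound 3 (0.40 log units; beyond the scatter) and amino in place of fluoro gives a 9.3-fold higher number from compound 1 to compound 3 (0.97 log units; beyond the scatter) as the widest step so far. The numbers therefore rise from fluoro through methylsulfanyl to amino, making compound 3 the weakest of the three. Nothing measured here explains this order. As far as these compounds go, whether the amino hydrogens matter remains open, as does how a dimethylamino or methoxy group at this carbon would compare.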